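From Propylamino to Isobutylamino: One Added Methyl

The source may hold more compounds than are shown below. What is called first, only, known or untested is meant among the compounds shown, and "the series" means these compounds.

Compound 1 `CCC1C(=O)N(C)c2cnc(Nc3ccc(S(=O)(=O)NCC(C)C)cc3)nc2N1c1ccn(C)n1` gives 5310 nM
Compound 2 `CCCNC(=O)c1ccc2c(ccn2-c2ncc3c(n2)N(c2ccn(C)n2)C(CC)C(=O)N3C)c1` gives 6160 nM

Both values come from a functional assay on HeLa cells (Homo sapiens) for antiproliferative activity, read by CCK-8 assay, with a stated time of 72 h; on this read-out higher numbers stand for weaker inhibition of growth and lower numbers for stronger inhibition of growth. Compound 2, at 6160 nM, sits within the usual scatter of compound 1, at 5310 nM, so repeated measurements could not tell these two compounds apart. Both show the same level of growth inhibition on this read-out.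

The next compound makes a very small change to compound 2. Compound 3 `CCC1C(=O)N(C)c2cnc(-n3ccc4cc(C(=O)NCC(C)C)ccc43)nc2N1c1ccn(C)n1` carries the difference (methyl in place of hydrogen on a saturated chain carbon bound to two saturated chain carbons). This is methyl in place of hydrogen on a saturated chain carbon bound to two saturated chain carbons, so propylamino becomes isobutylamino.

For the measured compounds named here, the measured compounds include no pair that differs in only one place, which leaves no direct example of what such a change does in this assay. The best starting point is therefore compound 2 at 6160 nM, and no step beyond the scatter is expected in either direction. The estimated change is a 1.1-fold lower number from compound 2 to compound 3 (0.05 log units; within the scatter), which is expected to stay within the scatter. For compound 3 the expected value is 5500 nM, with an estimated range from 2500 nM to 12000 nM.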

Compound 3, concentration for 50% growth inhibition: 4970 nM
For compound 3 the middle estimate is 1.1-fold (0.04 log units) above the measured one, and the stated range covers the measured number.
By their numbers in this assay, from the lowest: compounds 3, 1 and 2 (each within the scatter of the next).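

In this assay, replacing a hydrogen with a methyl on a saturated chain carbon bound to two saturated chain carbons turns propylamino into isobutylamino and gives a 1.2-fold lower number from compound 2 to compound 3 (0.09 log units; within the scatter), so repeated measurements could not separate the two compounds. For the compounds shown here, this is the first pair here that differs in only one place, and it gives the first direct reading of what this change does: at this position, the added methyl leaves growth inhibition indistinguishable from that of the propylamino compound. No supporting measurement is available that would explain this result.

A single small step shows only that this one added carbon makes no measurable difference, and it cannot show how much change this end of the chain can accept before the number moves beyond the scatter. From the compounds shown here alone, it remains open whether a longer chain, a cyclopropyl ring, an amine or a carboxylic acid at the same place would also stay within the scatter or would clearly strengthen or weaken growth inhibition.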